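Swapping a basic ring for an ester on the side chain

The compounds below may be only part of what the source reports. "The series", "measured", "known", "first", "only" and "open" are said of these compounds alone.

Compound 1 `CCN1CCN(C[C@H]2CN(c3ccc(-n4cc(-c5ccccn5)cn4)c(F)c3)C(=O)O2)CC1` — 2.19
Compound 2 `O=C1O[C@@H](CN2CCCCC2)CN1c1ccc(-n2cc(-c3ccccn3)cn2)c(F)c1` — 3.1
Compound 3 `O=C1CCC(=O)N1C[C@H]1CN(c2ccc(-n3cc(-c4ccccn4)cn3)c(F)c2)C(=O)O1` — 1.58

Of the compounds shown here, three sharing one core have been measured in a physicochemical assay for lipophilicity, read by HPLC, measured as octanol-water partition; on this read-out lower numbers stand for lower lipophilicity and higher numbers for higher lipophilicity. Compound 1 stands second highest of the three: compound 3 sits below it, and compound 2 sits above it, both gaps beyond the scatter. The two measured steps from compound 1 show how much this one side-chain position can move the number. Replacing the ethylpiperazine with piperidine raised it, a number 0.91 log units higher from compound 1 to compound 2 (beyond the scatter), while replacing it with the dioxopyrrolidine lowered it, a number 0.61 log units lower from compound 1 to compound 3 (beyond the scatter); the step between those two, a number 1.52 log units lower from compound 2 to compound 3 (beyond the scatter), is the largest in the set.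

Compound 4 `CC(=O)OC[C@H]1CN(c2ccc(-n3cc(-c4ccccn4)cn3)c(F)c2)C(=O)O1` is the next change from compound 1: acetoxy in place of 4-ethylpiperazin-1-yl on a saturated chain carbon bound to a saturated ring carbon. The entering group is smaller than the one it replaces and carries no ring; it is neither the saturated amine of compound 2 nor the two-carbonyl ring of compound 3, so the measured steps only bracket it rather than predict it directly. A modest step is expected, most likely upward, a number 0.26 log units higher from compound 1 to compound 4 (within the scatter). The estimate for compound 4 in this assay is 2.45, with a range from 1.85 to 3.05.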

Compound 4, partition coefficient: 2.09
Compound 4: middle estimate off by 0.36 log units, on the high side, within the range that was stated.
By their numbers in this assay, from the lowest: compound 3; then compounds 4 and 1 (each within the scatter of the next); then compound 2.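

In this assay, the 4-ethylpiperazin-1-yl group and the acetoxy group give readings that cannot be told apart, a number 0.10 log units lower from compound 1 to compound 4 (within the scatter), even though one has 8 heavy atoms and a ring and the other has 4 heavy atoms and no ring. The other two steps place the acetoxy compound clearly inside the span set by the two ring-bearing neighbours, a number 0.51 log units higher from compound 3 to compound 4 (beyond the scatter), and a number 1.01 log units lower from compound 2 to compound 4 (beyond the scatter), so at this place on a saturated chain carbon, a group without a ring can match one ring-bearing group while still differing clearly from two others. Nothing available here explains why these groups fall where they do.

On these data alone, what stays open is which part of the acetoxy group matters: a hydroxyl, a methoxy or a longer ester such as butanoyloxy in the same place would begin to separate the effect of the oxygen link from that of the acetyl carbons. A small open-chain amine such as dimethylamino, or a carboxylic acid, would also show whether the close match between compound 1 and compound 4 holds for other groups at this position.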